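Exchanging the aryl urea of compound 3 for cyclopentyl

The source may report more compounds than this note shows. Statements on the series, on what has been measured and on what is new or still open speak of the compounds shown alone.

Compound 3 `O=C(Nc1cccc(CNc2nccnc2Cl)c1)Nc1ccc(Cl)cc1Br` gives 7480 nM in a functional assay on MGC-803 cells (Homo sapiens) for antiproliferative activity, read by MTT assay, with a stated time of 48 h (on this read-out higher numbers stand for weaker inhibition and lower numbers for stronger inhibition), the lowest of the two numbers available there. Compound 1 `Cc1ccc(NC(=O)Nc2cccc(CNc3nccnc3Cl)c2)cc1C` gives 9870 nM in this assay, and the difference is small: a 1.3-fold lower number from compound 1 to compound 3 (0.12 log units; within the scatter). Compound 2 `O=C(Nc1cccc(CNc2nccnc2Cl)c1)NC1CCCCC1` reaches only the limit of this assay, at > 40000 nM.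

Compound 4 `O=C(Nc1cccc(CNc2nccnc2Cl)c1)NC1CCCC1` differs from compound 3 in one place: cyclopentyl in place of 2-bromo-4-chlorophenyl on an amide-type nitrogen. Within the data shown here, two measured steps bear on this change, each trading a six-membered aromatic ring on the amide-type nitrogen against a non-aromatic ring of carbon only, or the reverse. First, an at least 4.0-fold higher number from compound 1 to compound 2 (0.60 log units; beyond the scatter). Second, an at least 5.3-fold lower number from compound 2 to compound 3 (0.72 log units; beyond the scatter). Both point the same way: the saturated ring on that nitrogen goes with weaker inhibition, to the extent that compound 2 ends at the limit (the limit of > 40000 nM in this assay, at which 1 of the 3 values shown sits). Cyclopentyl is a non-aromatic ring of carbon only, like cyclohexyl, so the step from compound 3 to compound 4 is expected to be a clear weakening of at least modest size, a 6.0-fold higher number from compound 3 to compound 4 (0.78 log units; beyond the scatter), quite possibly carrying compound 4 past the limit of this assay. Compound 4 is therefore estimated at 45000 nM, within a range from 15000 nM to 150000 nM.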

Compound 4, half-maximal inhibitory concentration: 23400 nM
The estimate for compound 4 lay 1.9-fold (0.28 log units) above the measured number; the measured number falls inside the stated range.
By their numbers in this assay, from the lowest: compounds 3 and 1 (each within the scatter of the next); then compound 4. At a limit, above all of these: compound 2.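

In this assay, a saturated ring on the amide-type nitrogen now carries a readable number rather than a limit, so its cost against the aryl ureas can be sized: there is a 3.1-fold higher number from compound 3 to compound 4 (0.50 log units; beyond the scatter), and a 2.4-fold higher number from compound 1 to compound 4 (0.37 log units; beyond the scatter). Both steps are modest, which shows that the exchange of either 2-bromo-4-chlorophenyl or 3,4-dimethylphenyl for cyclopentyl weakens inhibition without carrying the compound to the limit. Against cyclohexyl there is an at least 1.7-fold lower number from compound 2 to compound 4 (0.23 log units; that floor lies within the scatter), a floor that does not separate the two saturated rings, since compound 2 stands at a limit: the limit of > 40000 nM in this assay, at which 1 of the 4 values shown sits.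

From the compounds shown here alone, whether a smaller ring such as cyclopropyl, or an open chain such as n-butyl, on this nitrogen would give a number near that of cyclopentyl remains open, as does the effect of a ring carrying an amine there. Also open, going by these compounds, is whether an unsubstituted phenyl would stay with the two substituted aryl groups, whose numbers lie within the scatter of each other, or fall towards the saturated rings.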